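Aminophenyl Triazole Analogue of a Sesquiterpene Lactone Core

The source may report more compounds than this note shows. Statements on the series, on what has been measured and on what is new or still open speak of the compounds shown alone.

Compound 1 `C=C1C(=O)O[C@@H]2C=C(CCC(C)=O)[C@@H](C)CC[C@@H]12` gives > 50000 nM, a limit of the assay.
Compound 2 `C/C1=C\CC[C@@]2(C)O[C@@H]2[C@H]2OC(=O)[C@@H](Cn3cc(CO)nn3)[C@@H]2CC1` gives > 100000 nM, also a limit.
Compound 3 `C/C1=C\CC[C@@]2(C)O[C@@H]2[C@H]2OC(=O)[C@@H](Cn3cc(CCCCO)nn3)[C@@H]2CC1` gives > 100000 nM, again a limit.

In a functional assay on HL60/A cells (Homo sapiens) for cytotoxicity, read by flow cytometry and annexin V staining, with a stated time of 18 h (on this read-out lower numbers stand for stronger inhibition and higher numbers for weaker inhibition), every value shown is therefore a limit rather than a number. Compound 3 sits at the limit of > 100000 nM in this assay, at which 2 of the 3 values shown sit, while compound 1 sits at the limit of > 50000 nM in this assay, at which 1 of the 3 values shown sits. Within the data shown here, the only single-point step among the measured compounds, a step that the two limits leave unreadable from compound 2 to compound 3, cannot be read because both ends are limits. Compound 4 `C/C1=C\CC[C@@]2(C)O[C@@H]2[C@H]2OC(=O)[C@@H](Cn3cc(-c4cccc(N)c4)nn3)[C@@H]2CC1` differs from compound 3 in one place: 3-aminophenyl in place of 4-hydroxybutyl on an aromatic carbon. Among the measured compounds shown here, no measured step bears on this change, so there is no basis to expect a shift beyond the scatter. Compound 4 is therefore expected to stay near the limit, with an estimated step of a number no higher from compound 3 to compound 4 (the limit leaves the size open) and an estimated value of 100000 nM, ranging from 30000 nM to 300000 nM.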

Compound 4, half-maximal inhibitory concentration: > 100000 nM
Compound 4 gave a limit, no number (the forecaster's own chance of this, stated with the estimate: 70%); the middle value sits exactly at the limit.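

The steps among compound 2, compound 3 and compound 4 cannot be read: all three give limits, not numbers, in this assay. The compounds shown leave open whether any group at this place on the shared core would give a measurable value.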